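The source may report more compounds than this note shows. Statements on the series, on what has been measured and on what is new or still open speak of the compounds shown alone.

Compound 3 `CCCCCCCCCCc1ccc(-c2noc([C@H](CCCCN)NC(C)=O)n2)cc1` stands highest of the three measured compounds in an assay on HeLa cells for inhibition of sphingosine-1-phosphate transporter SPNS2 (Mus musculus), read by LC-MS, tested at 2 uM (on this read-out higher numbers stand for more inhibition at the one concentration tested (going by the name of the read-out) and lower numbers for less inhibition), where compound 3 gives 40%. Compound 1 `CCCCCCCCCCc1ccc(-c2noc(C(Cl)CCN)n2)cc1` gives 5%, and compound 2 `CCCCCCCCCCc1ccc(-c2noc(CC(CN)OC(C)=O)n2)cc1` gives 0%. The step of a number 35 percentage points higher from compound 1 to compound 3 (beyond the scatter) and the step of a number 40 percentage points higher from compound 2 to compound 3 (beyond the scatter) both show that the 1-acetamido-5-aminopentyl group carries the gain, whereas the step of a number 5 percentage points lower from compound 1 to compound 2 (within the scatter) between the two smaller chains is flat. Compound 4 `CCCCCCCCCCc1ccc(-c2noc(CCCN3CCCCC3)n2)cc1` differs from compound 3 by 3-(piperidin-1-yl)propyl in place of 1-acetamido-5-aminopentyl on an aromatic carbon, again at the same aromatic carbon. Since the two amine-bearing chains of compound 1 and compound 2 gave little, a large drop is expected for compound 4, a number 30 percentage points lower from compound 3 to compound 4 (beyond the scatter). Compound 4 is therefore estimated at 10%, within a range from 0% to 30%.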

Compound 4, a percentage reported as inhibition, at one concentration (the size of the read-out at that concentration, not a potency): 0%
Beside the measured number, compound 4's estimate is 10 percentage points above it; the measured number falls inside the stated range.
By their numbers in this assay, from the lowest: compounds 2, 4 and 1 (each within the scatter of the next); then compound 3.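

The change to 3-(piperidin-1-yl)propyl gives up the whole gain at this aromatic carbon, with a number 40 percentage points lower from compound 3 to compound 4 (beyond the scatter) as the step. The steps of no change at the digits printed from compound 2 to compound 4 (within the scatter) and a number 5 percentage points lower from compound 1 to compound 4 (within the scatter) put compound 4 level with both other compounds, so a chain with a six-membered non-aromatic ring does not recover what 1-acetamido-5-aminopentyl gives. No evidence is available that accounts for this result.

From the compounds shown here alone, whether the gain rests on the acetamido group, the terminal amine or the chain length stays open. A plain 5-aminopentyl chain, or the opposite configuration at the stereocentre, would help separate these.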